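This account rests on a few compounds, and the source may have more. Where it says the series, first, only, none or still open, it means among the compounds named here.

Measured in a functional assay on CLL cells (Homo sapiens) for cytotoxicity, read by MTT assay, with a stated time of 48 h; on this read-out higher numbers stand for an effect only at larger amounts of compound and lower numbers for an effect already at smaller amounts:
- compound 1 `C=C(CC)C(=O)c1ccc(OCC(=O)Nc2cccc(C(=O)O)c2)c(Cl)c1Cl`: 20600 nM
- compound 2 `C=C(CC)C(=O)c1ccc(OCC(=O)Nc2ccc(C(=O)O)cc2)c(Cl)c1Cl`: 5000 nM
- compound 3 `C=C(CC)C(=O)c1ccc(OCC(=O)Nc2ccc(C#N)cc2)c(Cl)c1Cl`: 7800 nM

Compound 3 cannot be told apart from one of the others, with a 1.6-fold higher number from compound 2 to compound 3 (0.19 log units; within the scatter), but it is separated from the remaining one, with a 2.6-fold lower number from compound 1 to compound 3 (0.42 log units; beyond the scatter).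

Compound 4 `C=C(CC)C(=O)c1ccc(OCC(=O)NO)c(Cl)c1Cl` carries hydroxy in place of 4-cyanophenyl on an amide-type nitrogen.

Among the compounds with values here, the steps that bear on this change are those at the same nitrogen, a 4.1-fold lower number from compound 1 to compound 2 (0.61 log units; beyond the scatter) and a 2.6-fold lower number from compound 1 to compound 3 (0.42 log units; beyond the scatter). From the compounds shown here alone, both are modest, but in each an aromatic ring stays on the nitrogen, so the data do not cover its removal and the direction remains open. A small change is expected: a 1.1-fold lower number from compound 3 to compound 4 (0.05 log units; within the scatter). The estimate for compound 4 is 7000 nM, with an expected range from 2500 nM to 20000 nM.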

Compound 4, half-maximal effective concentration: 4500 nM
Compound 4: the middle estimate sits 1.6-fold (0.19 log units) above what was measured, and the stated range covers the measured number.
By their numbers in this assay, from the lowest: compounds 4, 2 and 3 (each within the scatter of the next); then compound 1.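

Removing the whole aromatic ring from the amide-type nitrogen does not cost effect in this assay: a 1.7-fold lower number from compound 3 to compound 4 (0.24 log units; within the scatter) and a 1.1-fold lower number from compound 2 to compound 4 (0.05 log units; within the scatter) both stay within the scatter even though hydroxy is far smaller than the 4-cyanophenyl it replaces. Only the 3-carboxyphenyl compound stands apart, with a 4.6-fold lower number from compound 1 to compound 4 (0.66 log units; beyond the scatter) beyond the scatter. No measurement offered here explains this tolerance.

Open, from the compounds shown here alone, is whether the hydroxy itself matters, or whether a methoxy group, an amino group or a short alkyl chain on this nitrogen would give the same level.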